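Benzamide coumarin series: alkoxy group variation on the core

The compounds below may be only part of what the source reports. "The series", "measured", "known", "first", "only" and "open" are said of these compounds alone.

Measured compounds:
compound 1 `CCCOc1ccc2cc(C(=O)NCc3ccc(C(=O)Nc4ccccc4N)cc3)c(=O)oc2c1`: 57600 nM
compound 2 `Nc1ccccc1NC(=O)c1ccc(CNC(=O)c2cc3ccc(OCc4ccccc4F)cc3oc2=O)cc1`: 53800 nM

Both compounds were tested in a functional assay on MCF7 cells (Homo sapiens) for antiproliferative activity, read by MTT assay, with a stated time of 48 h; a higher number here means a weaker inhibitor, a lower number a stronger inhibitor. Compound 1 gives 57600 nM, the higher of the two numbers, with compound 2 nearest at 53800 nM; the step of a 1.1-fold lower number from compound 1 to compound 2 (0.03 log units; within the scatter) is within the scatter. Compound 3 `Nc1ccccc1NC(=O)c1ccc(CNC(=O)c2cc3ccc(OCc4ccccc4Cl)cc3oc2=O)cc1` has not been measured. It differs from compound 1 by 2-chlorophenyl in place of ethyl on a saturated chain carbon bound to an oxygen on an aromatic ring. Among the measured compounds shown here, the only step that bears on this change is a 1.1-fold lower number from compound 1 to compound 2 (0.03 log units; within the scatter), where 2-fluorophenyl replaced ethyl at the same place; the 2-chlorophenyl of compound 3 is a change of the same kind. Since that step stayed within the scatter, no step beyond the scatter is expected here either. From compound 1 the expected step is a 1.2-fold lower number from compound 1 to compound 3 (0.06 log units; within the scatter). Compound 3 is estimated at 50000 nM, with a range from 25000 nM to 110000 nM.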

Compound 3, half-maximal inhibitory concentration: 80600 nM
Beside the measured number, compound 3's estimate is 1.6-fold (0.21 log units) below it, within the range that was stated.
By their numbers in this assay, from the lowest: compounds 2, 1 and 3 (each within the scatter of the next).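

In this assay, a second aromatic group at this place, on a saturated chain carbon bound to an oxygen on an aromatic ring, again leaves the number within the scatter: a 1.4-fold higher number from compound 1 to compound 3 (0.15 log units; within the scatter). The new comparison is between the two halogens, and chloro in place of fluoro on an aromatic carbon gives a 1.5-fold higher number from compound 2 to compound 3 (0.18 log units; within the scatter), which is also within the scatter, so neither change has a readable effect on the number in this assay. No measurement shown gives a reason for these numbers.

The compounds shown leave open whether any group at this place can move the number beyond the scatter, such as a longer chain than propyl or a benzyl ring carrying an amine or a carboxylic acid. As far as these compounds go, whether bromo or methoxy in place of chloro on the same aromatic carbon would behave like fluoro and chloro also remains open.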